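The source may report more compounds than this note shows. Statements on the series, on what has been measured and on what is new or still open speak of the compounds shown alone.

Compound 1 `O=C(Nc1ccc(Cl)c(-c2nnc3c(Cl)cccn23)c1)c1ccccc1`: in a functional assay on T47D cells (Homo sapiens) for antiproliferative activity, read by MTT assay, with a stated time of 72 h (a higher number here means a weaker inhibitor, a lower number a stronger inhibitor), compound 1 gives only the assay limit > 100000 nM.
Compound 2 `O=C(Nc1ccc(Cl)c(-c2nnc3c(Cl)cccn23)c1)c1c(F)cccc1Cl`: in this assay compound 2 gives only the assay limit > 100000 nM.
Compound 3 `O=C(Nc1ccc(Cl)c(-c2nnc3c(Cl)cccn23)c1)c1ccc(C(F)(F)F)cc1Cl`: in this assay compound 3 gives only the assay limit > 100000 nM.

All three compounds share one core and differ only in the ring attached to the carbonyl carbon. None of them gave a readable number: every value is a limit of the assay, so compound 3 stands exactly where the other two stand, and nothing separates it from them (the limit of > 100000 nM in this assay, at which 3 of the 3 values shown sit). Among the measured compounds shown here, the one step recorded on the carbonyl ring, a step that the two limits leave unreadable from compound 1 to compound 2, is unreadable for the same reason.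

Compound 4 `O=C(Nc1ccc(Cl)c(-c2nnc3c(Cl)cccn23)c1)c1ccc(F)cc1Cl` is not yet measured. It differs from compound 3 only at the carbonyl ring: fluoro in place of trifluoromethyl on an aromatic carbon. For the measured compounds named here, no measured step speaks to this change, since the step from compound 1 to compound 2 gives no size at all. Going by the values given here, the only guide is that every change tried so far on this ring has left the value at the limit. The step from compound 3 to compound 4 is therefore expected to be a number no higher from compound 3 to compound 4 (the limit leaves the size open), most likely no readable change. Compound 4 is estimated at 100000 nM, with a range from 20000 nM to 500000 nM, and it will most probably again be reported only as a limit.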

Compound 4, half-maximal inhibitory concentration: > 100000 nM
Compound 4: no number, only a limit (the forecaster's own chance of this, stated with the estimate: 85%); the middle value sits exactly at the limit.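

Compound 4 joins compounds 1, 2 and 3 at the same assay limit, so no step among these four compounds can be read: the limit of > 100000 nM in this assay, at which 4 of the 4 values shown sit.

The compounds shown leave open whether any ring on the carbonyl carbon of the shared core gives a readable value in this assay, and how large any such difference would be.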